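Fluoro Added Once More, on a Second Core

This account rests on a few compounds, and the source may have more. Where it says the series, first, only, none or still open, it means among the compounds named here.

The measured compounds and their values in an assay on CHO cells for antagonist activity at transient receptor potential cation channel subfamily V member 1 (Homo sapiens), read by FLIPR; a lower number here means a stronger inhibitor, a higher number a weaker inhibitor:
compound 1, `CC(C(=O)NCc1ccc(C(F)(F)F)cc1N1CCC(Cc2ccccc2)CC1)c1ccc(NS(C)(=O)=O)c(F)c1`: 1.4 nM
compound 2, `CC(C(=O)NCc1ccc(C(F)(F)F)cc1N1CCC(Cc2ccc(F)cc2)CC1)c1ccc(NS(C)(=O)=O)c(F)c1`: 0.4 nM
compound 3, `CC(C(=O)NCc1ccc(C(F)(F)F)cc1-c1cccc(Cl)c1)c1ccc(NS(C)(=O)=O)c(F)c1`: 1 nM

Compound 1 and compound 2 share a core and differ in one place only, (fluoro in place of hydrogen on an aromatic carbon). That change gave a 3.5-fold lower number from compound 1 to compound 2 (0.54 log units; beyond the scatter), a step that lies beyond the usual scatter of this assay.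

Compound 3 carries a different core; how it differs from compound 1 is not broken down here. In this assay compound 3 gives a number close to that of compound 1, the gap between the two lying within the scatter, while compound 2 sits beyond the scatter from both of them.

Compound 4, `CC(C(=O)NCc1ccc(C(F)(F)F)cc1-c1ccc(F)c(Cl)c1)c1ccc(NS(C)(=O)=O)c(F)c1`, has not yet been measured. It differs from compound 3 by fluoro in place of hydrogen on an aromatic carbon. Among the compounds with values here, this is the same kind of change as the one from compound 1 to compound 2, but not the same: in compound 4 the entering fluoro stands ortho to a chloro group as well as para to a large group, whereas in compound 2 it stands para to a large group only. Within the data shown here, the one precedent on hand is the single step from compound 1 to compound 2, so the expectation rests on that alone, and on the two cores being different. Among the measured compounds shown here, compound 4 is expected to show a 2.0-fold lower number from compound 3 to compound 4 (0.30 log units; within the scatter), a step in the same direction as the earlier one and of a similar size, because a 3.5-fold lower number from compound 1 to compound 2 (0.54 log units; beyond the scatter) is the only guide available. For compound 4 the estimated value in this assay is 0.5 nM, with a range from 0.2 nM to 1.5 nM.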

Compound 4, inhibition constant: 0.6 nM
Beside the measured number, compound 4's estimate is 1.2-fold (0.08 log units) below it; measured number inside the range.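

Carried to the core of compound 3, fluoro in place of hydrogen on an aromatic carbon gave a 1.7-fold lower number from compound 3 to compound 4 (0.22 log units; within the scatter) in this assay, a step that on its own does not separate the two compounds. Set beside the step on the first core, the change does not read differently on the two cores: the same change on two cores in this assay, a 3.5-fold lower number (0.54 log units; beyond the scatter) from compound 1 to compound 2 and a 1.7-fold lower number (0.22 log units; within the scatter) from compound 3 to compound 4, 2.1-fold (0.32 log units) apart, within the scatter of two such steps

This is consistent with the change carrying over, but it does not prove that it does, since it rests on two pairs only, one of which stays within the scatter, and the entering fluoro of compound 4 stands ortho to a chloro group, which the entering fluoro of compound 2 does not. The compounds shown leave open whether another group on the same aromatic carbon, such as chloro, methoxy or a nitrile, would follow the same course on either core. They also leave open whether the 3-chloro-4-fluorophenyl group would keep its place in the series if the methanesulfonamide were exchanged for a carboxylic acid or an amine.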